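A few compounds are considered here, and "the series" means these few. Any claim that something is new, unique, unknown or untested is made for them only; others in the source may bear on it.

Measured so far in a functional assay on HeLa cells (Homo sapiens) for antiproliferative activity, read by MTT assay, with a stated time of 12 h; a lower number here means a stronger inhibitor, a higher number a weaker inhibitor:

Compound 1, `COc1ccc2oc(/C=C/c3ccc(OC(F)(F)F)cc3)cc(=O)c2c1`: compound 1 gives 9000 nM.
Compound 2, `COc1cc(OC)c2c(=O)cc(/C=C/c3ccccc3)oc2c1`: compound 2 gives 10100 nM.
Compound 3, `COc1cccc2oc(/C=C/c3ccc(OC(F)(F)F)cc3)cc(=O)c12`: compound 3 gives 9100 nM.

The three numbers lie close together. Compound 2 sits within the scatter of compound 1 and within the scatter of compound 3, so nothing sets it apart from either; the set so far reads as level. Within the data shown here, compound 1 and compound 3 each differ from compound 2 in more than one place, so no single step between measured compounds can be drawn, and the effect of a change on the phenyl ring alone has not been isolated anywhere in this set.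

Compound 4, `COc1cc(OC)c2c(=O)cc(/C=C/c3ccc(F)cc3)oc2c1`, is not yet measured. It differs from compound 2 by fluoro in place of hydrogen on an aromatic carbon. Among the measured compounds shown here, with no measured step to lean on, and with the three measured compounds all falling within the scatter of one another despite their differences on that ring, the step is expected to stay within the scatter, with no clear direction. The estimate is that from compound 2 to compound 4 the change is a 1.1-fold lower number from compound 2 to compound 4 (0.03 log units; within the scatter). Compound 4 is expected to give about 9500 nM in this assay, with a range from 4500 nM to 20000 nM.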

Compound 4, half-maximal inhibitory concentration: 14200 nM
Beside the measured number, compound 4's estimate is 1.5-fold (0.17 log units) below it, and the stated range covers the measured number.
By their numbers in this assay, from the lowest: compounds 1, 3, 2 and 4 (each within the scatter of the next).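

In this assay, among these compounds, a 1.4-fold higher number from compound 2 to compound 4 (0.15 log units; within the scatter) is the only step that isolates one change, phenyl to 4-fluorophenyl, and it lies within the scatter. On the core shared by compound 2 and compound 4, fluoro in place of hydrogen at this position, para to a large group on the six-membered aromatic ring of carbon only, therefore does not separate the two compounds, and this single step gives the change no direction. Nothing available here bears on why the two compounds read alike.

Still open, as far as these compounds go, is whether a hydroxyl, an amine or a carboxylic acid at this same position would move the number beyond the scatter, or whether this position stays as level for those groups as it does for fluoro. Also open, from the compounds shown here alone, is whether the same step from phenyl to 4-fluorophenyl would read alike on the core of compound 1 or of compound 3, where the methoxy group stands elsewhere.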